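Hydroxy to Methyl: Compound 3 Expected Close to Compound 2

This account rests on a few compounds, and the source may have more. Where it says the series, first, only, none or still open, it means among the compounds named here.

Two measured compounds set the scene. Compound 1 `O=C1OC[C@H](Cc2ccccc2O)[C@H]1Cc1ccc(Cl)c(Cl)c1` gives 33000 nM in a functional assay on HL-60 cells (Homo sapiens) for cytotoxicity, read by WST assay, with a stated time of 48 h; on this read-out higher numbers stand for an effect only at larger amounts of compound and lower numbers for an effect already at smaller amounts. Compound 2 `O=C1OC[C@H](Cc2cccc(O)c2)[C@H]1Cc1ccc(Cl)c(Cl)c1` gives 48000 nM in this assay. Going by the values given here, the one measured step, a 1.5-fold higher number from compound 1 to compound 2 (0.16 log units; within the scatter), leaves the two values within the scatter of each other, so compound 2 stands at the higher of the two numbers without any real distance to compound 1.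

Compound 3 `Cc1cccc(C[C@H]2COC(=O)[C@@H]2Cc2ccc(Cl)c(Cl)c2)c1` differs from compound 2 in one place: methyl in place of hydroxy on an aromatic carbon. Among the compounds with values here, no measured step exchanges hydroxy for methyl; the only recorded step replaces 2-hydroxyphenyl with 3-hydroxyphenyl and stays within the scatter, so it offers no guidance on direction. With nothing pointing either way, the expectation for compound 3 is a number near that of compound 2. For compound 3 the expected step is a 1.2-fold lower number from compound 2 to compound 3 (0.08 log units; within the scatter), within the scatter. The estimate for compound 3 in this assay is 40000 nM, ranging from 15000 nM to 110000 nM.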

Compound 3, half-maximal effective concentration: 22000 nM
Estimate against measurement, compound 3: 1.8-fold (0.26 log units) above; low and high end bracket the measured number.
By their numbers in this assay, from the lowest: compounds 3, 1 and 2 (each within the scatter of the next, the first and the last beyond it).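

In this assay, going by these compounds alone, hydroxy to methyl at this position gives the first step here that passes the scatter: a 2.2-fold lower number from compound 2 to compound 3 (0.34 log units; beyond the scatter) is a modest step, so at this position of the ring 3-methylphenyl and 3-hydroxyphenyl are not interchangeable. Against the 2-hydroxyphenyl group the picture differs: a 1.5-fold lower number from compound 1 to compound 3 (0.18 log units; within the scatter) shows no separation, so compound 3 keeps pace with compound 1 with no hydroxy on its ring at all. No measurement at hand accounts for the step from hydroxy to methyl.

From the compounds shown here alone, whether a methoxy group, a fluorine or an amine on the same aromatic carbon would fall with methyl or with hydroxy remains open. Going by these compounds, all three compounds also share the rest of the core, so it is equally open whether the step from hydroxy to methyl holds with another group elsewhere on it.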